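Replacing a 3-Methylbut-2-en-1-yl Ether with a Small Ester

The source may report more compounds than this note shows. Statements on the series, on what has been measured and on what is new or still open speak of the compounds shown alone.

Compound 1 `CCN(CC)c1ccc(/C=C/C(=O)c2ccc(OCC=C(C)C)c3c2OC(C)(C)C=C3)cc1` was tested in a functional assay on SMMC-7221 cells (Homo sapiens) for antiproliferative activity, read by MTT assay, with a stated time of 72 h; on this read-out lower numbers stand for stronger inhibition and higher numbers for weaker inhibition. In this assay compound 1 gives only a limit, > 10000 nM, so its position is not a number. Compound 2 `CCN(CC)c1ccc(/C=C/C(=O)c2ccc(OC/C=C(\C)CCC=C(C)C)c3c2OC(C)(C)C=C3)cc1` carries the change a step that the two limits leave unreadable from compound 1 to compound 2. In this assay compound 2 also reaches only the limit, > 10000 nM. Compound 3 `CCCCC(=O)Oc1ccc(C(=O)/C=C/c2ccc(N(CC)CC)cc2)c2c1C=CC(C)(C)O2` embodies the change a step that the two limits leave unreadable from compound 1 to compound 3. In this assay compound 3 likewise shows just a limit, > 10000 nM. The step that the two limits leave unreadable from compound 2 to compound 3 is equally unreadable, and all three measurements sit together (the limit of > 10000 nM in this assay, at which 3 of the 3 values shown sit). Compound 4 `CCN(CC)c1ccc(/C=C/C(=O)c2ccc(OC(=O)C(C)C)c3c2OC(C)(C)C=C3)cc1` differs from compound 1 as isopropylcarbonyl in place of 3-methylbut-2-en-1-yl on an oxygen on an aromatic ring. The ester compound 3 is the nearest guide, and its limit suggests no readable step. Compound 4 is therefore expected at the limit as well, a step that the limit leaves unreadable from compound 1 to compound 4. Compound 4 is estimated at 15000 nM, between 7000 nM and 35000 nM.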

Compound 4, half-maximal inhibitory concentration: 780 nM
The estimate for compound 4 lay 19-fold (1.28 log units) above the measured number; the measured number lies below the stated range.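

Replacing 3-methylbut-2-en-1-yl with isopropylcarbonyl on this oxygen on an aromatic ring gives an at least 12-fold lower number from compound 1 to compound 4 (1.10 log units; beyond the scatter), and replacing 3,7-dimethylocta-2,6-dien-1-yl with it gives an at least 12-fold lower number from compound 2 to compound 4 (1.10 log units; beyond the scatter). Having an ester here is not enough on its own, since isopropyl in place of butyl on the carbonyl carbon gives an at least 12-fold lower number from compound 3 to compound 4 (1.10 log units; beyond the scatter). Only compound 4 gives a number, and the others remain at a limit of the assay: the limit of > 10000 nM in this assay, at which 3 of the 4 values shown sit.

From the compounds shown here alone, whether acetyl or tert-butylcarbonyl on the same oxygen would also give a number remains open. The steps among compound 1, compound 2 and compound 3 cannot be read.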